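Working notes: from compound 2 to compound 4

The compounds below may be only part of what the source reports. "The series", "measured", "known", "first", "only" and "open" are said of these compounds alone.

Measured so far in a functional assay on HepG2 cells (Homo sapiens) for inhibition, read by sulforhodamine B assay, with a stated time of 74 h (on this read-out lower numbers stand for stronger inhibition and higher numbers for weaker inhibition), as follows
- compound 1 `Cc1ccc(S(=O)(=O)N2C(=O)C(C)OC23C=CC(=O)C=C3)cc1` gives 540 nM
- compound 2 `O=C1C=CC2(C=C1)OCC(=O)N2S(=O)(=O)c1ccc([N+](=O)[O-])cc1` gives > 10000 nM
- compound 3 `O=C1C=CC2(C=C1)OCC(=O)N2S(=O)(=O)c1ccc(F)c(F)c1` gives > 10000 nM

Compound 2 gives > 10000 nM as a limit of the assay and not a number. Thus the limit of > 10000 nM in this assay, at which 2 of the 3 values shown sit, is where compound 2 stands. Compound 4 `O=C1C=CC2(C=C1)OCC(=O)N2S(=O)(=O)c1ccc(C(F)(F)F)cc1` differs from compound 2 by trifluoromethyl in place of nitro on an aromatic carbon and carries trifluoromethyl in place of nitro on an aromatic carbon. Among the compounds with values here, no measured step covers this change, so the expectation in this assay is a small gain or none beyond the scatter, with the reading staying near the limit. The expectation leans on compound 3 at > 10000 nM as a second limit. The estimated change is an at least 1.2-fold lower number from compound 2 to compound 4 (0.09 log units; that floor lies within the scatter) as far as a limit allows. For compound 4 the expected value is 8000 nM with an estimated range of 1000 nM to 30000 nM as the likely span.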

Compound 4, half-maximal inhibitory concentration: 750 nM
Compound 4: the middle estimate sits 11-fold (1.03 log units) above what was measured; measured number outside the range, below it.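

In this assay, trifluoromethyl in place of nitro on an aromatic carbon, para to a large group, gives an at least 13-fold lower number from compound 2 to compound 4 (1.12 log units; beyond the scatter). Within the data shown here, this is the first single-place change, and it shows that the group at this position alone can separate a reading at the limit from a measured value. Compound 2 at > 10000 nM is a limit of the assay and not a number, so the step is a floor only: the limit of > 10000 nM in this assay, at which 2 of the 4 values shown sit.

On these data alone, whether an amine or a carboxylic acid at this position would read nearer compound 4 or compound 2 stays open. As far as these compounds go, compound 1 differs from compound 4 in more than one place, so the share of each of its methyl groups also stays open.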